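This account rests on a few compounds, and the source may have more. Where it says the series, first, only, none or still open, it means among the compounds named here.

Working notes on the series in a functional assay on HepG2 cells (Homo sapiens) for inhibition, read by MTT assay, with a stated time of 72 h; a lower number here means a stronger inhibitor, a higher number a weaker inhibitor. Compound 1 `CN(C(=O)NC(=O)c1cccc(C(F)(F)F)c1)c1nc(C(F)(F)F)c(C(=O)N/N=C/c2cccc(C(F)(F)F)c2)s1` gives 5.79 ug/mL there, and compound 3 `CN(C(=O)NC(=O)c1ccccc1F)c1nc(C(F)(F)F)c(C(=O)N/N=C/c2ccc(C(F)(F)F)cc2)s1` gives 4.56 ug/mL; the two sit within the usual scatter of each other. Compound 2 `Cc1nc(N(C)C(=O)NC(=O)c2c(F)cccc2F)sc1C(=O)N/N=C/c1ccc(C(F)(F)F)cc1` is reported only as a limit in this assay, > 100 ug/mL, and so stands apart from the other two measured compounds; the limit of > 100 ug/mL in this assay, at which 1 of the 3 values shown sits, marks where it sits. Compound 4 `COc1ccc(/C=N/NC(=O)c2sc(N(C)C(=O)NC(=O)c3c(F)cccc3F)nc2C)cc1` has not been measured in this assay. It differs from compound 2 by methoxy in place of trifluoromethyl on an aromatic carbon. Going by the values given here, no measured step between compounds shows the effect of this change, so little shift beyond the scatter is expected, and the step of an at least 1.1-fold lower number from compound 2 to compound 4 (0.04 log units; that floor lies within the scatter) is written as an estimate only. Compound 4 is estimated at 90 ug/mL, in a range from 25 ug/mL to 200 ug/mL.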

Compound 4, half-maximal inhibitory concentration: 22.7 ug/mL
Compound 4: middle estimate off by 4.0-fold (0.60 log units), on the high side; the whole stated range lies above it.
By their numbers in this assay, from the lowest: compounds 3 and 1 (each within the scatter of the next); then compound 4. At a limit, above all of these: compound 2.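

Methoxy in place of trifluoromethyl, on an aromatic carbon para to a large group, gives the first readable step at this position in this assay: an at least 4.4-fold lower number from compound 2 to compound 4 (0.64 log units; beyond the scatter). This step is a floor only, set by the limit for compound 2: the limit of > 100 ug/mL in this assay, at which 1 of the 4 values shown sits. With methoxy at this position, compound 4 gives a measured number, 22.7 ug/mL.

On these data alone, the full size of the step stays open, as does whether it carries over to the other substituents on the core. As far as these compounds go, whether an amine or a hydroxyl at this position would match methoxy also remains open.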